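Aziridinylquinone series: carbamate chain in place of cyclohexyl

The source may hold more compounds than are shown below. What is called first, only, known or untested is meant among the compounds shown, and "the series" means these compounds.

Measured so far:
compound 1, `CC1=C(N2CC2)C(=O)C(Cc2ccccc2)=C(N2CC2)C1=O`: 4.85
compound 2, `CC1=C(N2CC2)C(=O)C(C2CCCCC2)=C(N2CC2)C1=O`: 5.82

Within the data shown here, in a functional assay on L1210 cells (Mus musculus), with a stated time of 12 days (on this read-out higher numbers stand for higher potency (the scale is a negative logarithm) and lower numbers for lower potency), compound 2 stands highest of the two numbers, with compound 1 the nearest and the single step of a number 0.97 log units higher from compound 1 to compound 2 (beyond the scatter) separating them. Compound 3, `CC1=C(N2CC2)C(=O)C(C(C)COC(N)=O)=C(N2CC2)C1=O`, is not yet measured. The change from compound 2 is a group of 7 heavy atoms (4 carbon, 1 nitrogen, 2 oxygen; no ring) in place of a group of 6 heavy atoms (6 carbon; one six-membered non-aromatic ring of carbon only), on a double-bonded ring carbon. Among the measured compounds shown here, no measured step covers a carbamate-bearing chain; the only guide is that the ring-for-ring swap a number 0.97 log units higher from compound 1 to compound 2 (beyond the scatter) was modest, so a group with no ring is expected to sit somewhere between the two values, with wide uncertainty. For compound 3 the expected step is a number 0.42 log units lower from compound 2 to compound 3 (beyond the scatter). Compound 3 is estimated at 5.4, within 4.6 to 6.2.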

Compound 3, logarithm of the reciprocal of the active concentration, log(1/C): 6.41
Compound 3: middle estimate off by 1.01 log units, on the low side; the whole stated range lies below it.
By their numbers in this assay, from the lowest: compound 1; then compound 2; then compound 3.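

In this assay, a ring is not required on this double-bonded ring carbon: the open chain gives a number 0.59 log units higher from compound 2 to compound 3 (beyond the scatter) and also a number 1.56 log units higher from compound 1 to compound 3 (beyond the scatter) in the comparison with benzyl. Among these compounds, the entering group is the first at this position to carry nitrogen and oxygen, with 1 hydrogen-bond donor and 2 hydrogen-bond acceptors against none on cyclohexyl. Nothing available accounts for these steps.

On these data alone, whether they belong to the carbamate end or to the carbon chain bearing it stays open. A chain ending in a hydroxyl or an amine, or a longer chain, would bear on this.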